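A few compounds are considered here, and "the series" means these few. Any claim that something is new, unique, unknown or untested is made for them only; others in the source may bear on it.

Measured so far in a functional assay on the whole organism (strain Wistar) for inhibition, with Rattus norvegicus as the target, read by paw edema, with a stated time of 1 h, at a dose of 10 mg/kg by the intraperitoneal route; on this read-out lower numbers stand for less inhibition and higher numbers for more inhibition at the one dose given (going by the name of the read-out):
compound 1 `CC(=O)Nc1ccc(O)c(C(=O)OCCn2c([N+](=O)[O-])cnc2C)c1` – 63.4%
compound 2 `Cc1ncc([N+](=O)[O-])n1CCOC(=O)c1cc(NC(=O)[C@H](C)NC(=O)OCc2ccccc2)ccc1O` – 58.5%

In this assay compound 1 gives 63.4% and compound 2 gives 58.5%. The two numbers lie within the scatter of each other, so compound 2 is not set apart from compound 1 on the numbers shown. Compound 3 `Cc1ncc([N+](=O)[O-])n1CCOC(=O)c1cc(NC(=O)CNC(=O)OCc2ccccc2)ccc1O` differs from compound 2 by hydrogen in place of methyl on a saturated chain carbon bound to an amide-type nitrogen and a carbonyl carbon. No measured pair shows a step of this kind in this assay. The step from compound 2 to compound 3 is expected to stay within the scatter, with no clear direction, estimated at a number 0.5 percentage points lower from compound 2 to compound 3 (within the scatter). Compound 3 is expected to give 58% in this assay, in a range from 45% to 70%.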

Compound 3, a percentage reported as inhibition, in the whole organism at one dose (the size of the read-out at that dose, not a potency): 56.1%
Compound 3: the middle estimate sits 1.9 percentage points above what was measured; low and high end bracket the measured number.
By their numbers in this assay, from the lowest: compounds 3, 2 and 1 (each within the scatter of the next).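

In this assay, hydrogen in place of methyl on a saturated chain carbon bound to an amide-type nitrogen and a carbonyl carbon gives a number 2.4 percentage points lower from compound 2 to compound 3 (within the scatter) and so does not separate the two compounds. Likewise, (benzyloxycarbonyl)amino in place of hydrogen on a saturated chain carbon bound to a carbonyl carbon gives a number 7.3 percentage points lower from compound 1 to compound 3 (within the scatter) and so leaves this read-out unresolved at the one dose. No supporting data bear on why these changes stay so small.

Going by these compounds, whether an amine, a carboxylic acid or a longer chain at this saturated chain carbon would move the number beyond the scatter remains open.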